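A few compounds are considered here, and "the series" means these few. Any claim that something is new, unique, unknown or untested is made for them only; others in the source may bear on it.

In a functional assay on MCF7 cells (Homo sapiens) for cytotoxicity, read by MTT assay, with a stated time of 48 h (a lower number here means a stronger inhibitor, a higher number a weaker inhibitor), compound 1 `O=C1/C(=C\c2ccc([N+](=O)[O-])cc2)S/C(=N/c2ccccc2)N1Cc1ccncc1` gives 13000 nM, while compound 2 `O=C1/C(=C\c2cccc(O)c2)S/C(=N/c2ccccc2)N1Cc1ccncc1` gives 43600 nM. Compound 2 therefore has the higher of the two numbers, making it the weaker inhibitor so far. Compound 3 `Cc1ccc(/C=C2/S/C(=N/c3ccccc3)N(Cc3ccncc3)C2=O)s1` differs from compound 2 in one place: 5-methylthiophen-2-yl in place of 3-hydroxyphenyl on a double-bonded chain carbon bound to a double-bonded ring carbon. Here, 5-methylthiophen-2-yl takes the place of 3-hydroxyphenyl on a double-bonded chain carbon bound to a double-bonded ring carbon. For the measured compounds named here, only one measured step changes the group at this place: a 3.4-fold higher number from compound 1 to compound 2 (0.53 log units; beyond the scatter). That step is modest but beyond the scatter, so a swap here can shift the number. Going by the values given here, it is thin evidence, however, and no measured compound carries the incoming group. Since compound 2 has the higher number, a modest move towards a lower number in this assay is expected. The expected change is a 2.2-fold lower number from compound 2 to compound 3 (0.34 log units; beyond the scatter). For compound 3 the estimate is 20000 nM, with an expected range of 7000 nM to 50000 nM.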

Compound 3, half-maximal inhibitory concentration: 28700 nM
For compound 3 the middle estimate is 1.4-fold (0.16 log units) below the measured one; measured number inside the range.
By their numbers in this assay, from the lowest: compound 1; then compounds 3 and 2 (each within the scatter of the next).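

In this assay the swap of 3-hydroxyphenyl for 5-methylthiophen-2-yl gives a 1.5-fold lower number from compound 2 to compound 3 (0.18 log units; within the scatter) and so separates these two compounds by no reliable margin, even though a six-membered carbon ring with a hydrogen-bond donor leaves and a five-membered sulfur-containing ring without one enters. Measured against the 4-nitrophenyl group, the same incoming group gives a 2.2-fold higher number from compound 1 to compound 3 (0.34 log units; beyond the scatter) and so, among these three compounds, only compound 1 stands clear of the other two. Nothing measured here explains why the numbers fall this way. From the compounds shown here alone, it remains open whether the nitro group itself sets compound 1 apart, or whether any phenyl or thiophene ring at this place would do the same. An amine or a carboxylic acid on the ring, or an open alkyl chain replacing it, could test how much this place tolerates.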